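The compounds below may be only part of what the source reports. "The series", "measured", "known", "first", "only" and "open" are said of these compounds alone.

Measured so far in an ADME assay on BJ cells (Homo sapiens) for cytotoxicity, with a stated time of 72 h; a lower number here means that less compound is needed, a higher number that more compound is needed for the effect:
- Compound 1 `COc1cc2ncnc(-n3nc(-c4ccccn4)nc3N)c2cc1N`: "not determined" (no result reported)
- Compound 2 `COc1cc2ncnc(-n3nc(-c4ccccn4)nc3N)c2cc1OCCCNC(=O)OC(C)(C)C`: > 12000 nM
- Compound 3 `COc1cc2ncnc(-n3nc(-c4ccccn4)nc3N)c2cc1OCCCNC(=O)OC(C)C`: > 13000 nM

Compound 3 has no exact reading on these numbers. Its entry of > 13000 nM is a limit of the assay, not a number. Compound 2 likewise reaches only a limit, > 12000 nM. Compound 1 offers no comparison, since its entry reads "not determined" (no result reported).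

The next compound, compound 4 `COc1cc2ncnc(-n3nc(-c4ccccn4)nc3N)c2cc1OCCCNC(=O)C(F)(F)F`, has not yet been measured. It replaces isopropoxy with trifluoromethyl on a carbonyl carbon whose other neighbour is an amide-type nitrogen: trifluoromethyl in place of isopropoxy on a carbonyl carbon.

Going by the values given here, only one measured step bears on this change, and it is a step that the two limits leave unreadable from compound 2 to compound 3. That step also alters the isopropoxy end of the chain, but it supplies no size that could be carried over. With no readable size to draw on, no step beyond the scatter is expected in this assay, and no direction is expected either. The estimated step is an at least 1.0-fold lower number from compound 3 to compound 4 (0.03 log units; that floor lies within the scatter). A report of only a limit is considered the likelier outcome for the new compound. For compound 4 the estimated value is 12000 nM, with an expected range from 5000 nM to 25000 nM.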

Compound 4, half-maximal effective concentration: > 7000 nM
Compound 4 ended at the assay's limit; the forecaster's own chance of this, stated with the estimate: 70%; the middle value lies beyond the limit too.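

In this assay compound 4 gives > 7000 nM, a limit of the assay and not a number. As compound 2 and compound 3 also stand at limits, the steps from either of them to compound 4 cannot be read. The compounds shown leave open whether trifluoromethyl in place of isopropoxy or tert-butoxy on a carbonyl carbon shifts this read-out at all, and in which direction.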